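Aryl variation on the ring nitrogen: toward compound 4

The source may hold more compounds than are shown below. What is called first, only, known or untested is meant among the compounds shown, and "the series" means these compounds.

Compound 1, `N#CC1=C(N)Oc2c(c3nc4ccccc4nc3c3ccccc23)C12C(=O)N(Cc1cnnn1-c1ccccc1Cl)c1ccccc12`, gives in a functional assay on HCT-116 cells (Homo sapiens) for antiproliferative activity, read by MTT assay, with a stated time of 48 h (a lower number here means a stronger inhibitor, a higher number a weaker inhibitor), only the limit > 50000 nM.
Compound 2, `N#CC1=C(N)Oc2c(c3nc4ccccc4nc3c3ccccc23)C12C(=O)N(Cc1cnnn1-c1cccc(Cl)c1)c1ccccc12`, gives in this assay only the limit > 50000 nM.
Compound 3, `COc1ccc(-n2nncc2CN2C(=O)C3(C(C#N)=C(N)Oc4c3c3nc5ccccc5nc3c3ccccc43)c3ccccc32)cc1`, gives in this assay only the limit > 50000 nM.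

Compound 3 stands where every measured member of the series stands: at a limit rather than a number. The three values shown share (the limit of > 50000 nM in this assay, at which 3 of the 3 values shown sit), so no ordering among compounds 1, 2 and 3 can be read. The steps a step that the two limits leave unreadable from compound 1 to compound 2, a step that the two limits leave unreadable from compound 1 to compound 3 and a step that the two limits leave unreadable from compound 2 to compound 3 are each unreadable for that reason, and none of them tells how a change of the aryl group on the ring nitrogen moves the read-out.

Compound 4, `Cc1ccc(C)c(-n2nncc2CN2C(=O)C3(C(C#N)=C(N)Oc4c3c3nc5ccccc5nc3c3ccccc43)c3ccccc32)c1`, differs from compound 3 by 2,5-dimethylphenyl in place of 4-methoxyphenyl on an aromatic nitrogen. The measured steps that bear on this position, from compound 1 to compound 2, from compound 1 to compound 3 and from compound 2 to compound 3, all sit between limits and give no size. There is thus no measured basis for expecting any step beyond the scatter in this assay in either direction, and the most likely outcome is a further limit.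

The expected step is a number no higher from compound 3 to compound 4 (the limit leaves the size open). Compound 4 is estimated at 50000 nM, with a range from 20000 nM to 100000 nM.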

Compound 4, half-maximal inhibitory concentration: > 50000 nM
Compound 4: no number, only a limit; the forecaster's own chance of this, stated with the estimate: 85%; the middle value sits exactly at the limit.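

In this assay compound 4 gives > 50000 nM as a limit, not a number. The steps to compound 4 from compounds 1, 2 and 3 therefore cannot be read: the limit of > 50000 nM in this assay, at which 4 of the 4 values shown sit. The compounds shown leave open how the aryl group on the ring nitrogen moves the read-out, and at what concentration any of them inhibits.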